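This account rests on a few compounds, and the source may have more. Where it says the series, first, only, none or still open, it means among the compounds named here.

Measured set in a functional assay on A-375 cells (Homo sapiens) for cytotoxicity, read by MTT assay; on this read-out higher numbers stand for weaker inhibition and lower numbers for stronger inhibition:
compound 1, `O=S(=O)(NCCCNc1nccc(-c2c(-c3cccc(F)c3)nc3sccn23)n1)c1ccc(F)cc1`: 14500 nM
compound 2, `O=S(=O)(NCCNc1nccc(-c2c(-c3cccc(F)c3)nc3sccn23)n1)c1ccc(Br)cc1`: 13500 nM
compound 3, `O=S(=O)(NCCCNc1nccc(-c2c(-c3cccc(F)c3)nc3sccn23)n1)c1ccccc1`: 6600 nM

Compound 2 gives the second highest of the three numbers. Its nearest neighbour is compound 1, separated by a 1.1-fold lower number from compound 1 to compound 2 (0.03 log units; within the scatter); its furthest is compound 3, separated by a 2.0-fold lower number from compound 2 to compound 3 (0.31 log units; beyond the scatter). The remaining step on record, a 2.2-fold lower number from compound 1 to compound 3 (0.34 log units; beyond the scatter), is also modest.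

Compound 4, `Cc1ccc(C(=O)NCCNc2nccc(-c3c(-c4cccc(F)c4)nc4sccn34)n2)cc1`, is still to be measured in this assay. It differs from compound 2 as follows: (4-methylphenyl)carbonyl in place of (4-bromophenyl)sulfonyl on an amine nitrogen. Going by the values given here, none of the measured steps bears directly on this exchange. The steps from compound 1 to compound 2 and from compound 2 to compound 3 alter the aryl halogen together with the chain, and the step from compound 1 to compound 3 alters only the fluoro; all three compounds keep the sulfonyl linkage, so the move from sulfonyl to carbonyl is unprobed here. Given that every step seen in the set is modest, the expected step of a 1.4-fold lower number from compound 2 to compound 4 (0.13 log units; within the scatter) is taken as within the scatter or modest, with no direction preferred. Compound 4 is therefore estimated at 10000 nM, with an expected range from 3000 nM to 40000 nM.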

Compound 4, half-maximal inhibitory concentration: 5880 nM
For compound 4 the middle estimate is 1.7-fold (0.23 log units) above the measured one; the range from low to high includes it.
By their numbers in this assay, from the lowest: compounds 4 and 3 (each within the scatter of the next); then compounds 2 and 1 (each within the scatter of the next).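

In this assay, (4-methylphenyl)carbonyl in place of (4-bromophenyl)sulfonyl on the amine nitrogen gives a 2.3-fold lower number from compound 2 to compound 4 (0.36 log units; beyond the scatter) and so provides the first read on this linkage, showing that the sulfonyl group shared by compounds 1, 2 and 3 is not needed to retain cytotoxicity in this series. The step from compound 3 gives a 1.1-fold lower number from compound 3 to compound 4 (0.05 log units; within the scatter) and leaves the two compounds level, while the step from compound 1 gives a 2.5-fold lower number from compound 1 to compound 4 (0.39 log units; beyond the scatter) and remains modest, but both also change the chain and the aryl substituent, so neither isolates the carbonyl. No supporting data are available to explain the shift in this cell read-out.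

The exchange alters the linking group and the aryl substituent together, so (4-bromophenyl)carbonyl and (4-methylphenyl)sulfonyl on the same chain remain the open pair for separating the two contributions. Also open, as far as these compounds go, is whether a carboxylic acid or an amine on the aromatic ring of the carbonyl series, or a longer chain carrying (4-methylphenyl)carbonyl, would move the number beyond the modest steps seen so far.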